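A few compounds are considered here, and "the series" means these few. Any claim that something is new, unique, unknown or untested is made for them only; others in the source may bear on it.

Compound 1 `O=C1N/C(=N/c2ccc(Cl)cc2)S/C1=C\c1ccccn1`: 41.7%
Compound 2 `O=C1N/C(=N\c2ccccc2[N+](=O)[O-])S/C1=C/c1ccccn1`: 36.7%

Both measured compounds were tested in a functional assay on the whole organism (strain Swiss albino) for inhibition, with Mus musculus as the target, in the writhing test, with stated times of 30 min and 15 min, at a dose of 50 mg/kg by the oral route; a higher number here means more inhibition at the dose given (going by the name of the read-out), a lower number less inhibition. Compound 1 stands at the top of the two numbers with 41.7% in this assay, but compound 2, with 36.7% in this assay, lies within the usual scatter of that figure, so the two results cannot be separated. For the measured compounds named here, no pair of measured compounds differs in only one place, so no single measured step is available to guide any prediction.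

Compound 3 `O=C1N/C(=N/c2ccccc2Cl)S/C1=C\c1ccccn1` has not yet been measured in this assay. It holds the same atoms as compound 1, joined differently: 2-chlorophenyl in place of 4-chlorophenyl on a double-bonded nitrogen. The only reference points are the two measured compounds, which carry different groups on the double-bonded nitrogen and yet give values within the scatter of each other. On that basis the step is expected to be a number 1.7 percentage points lower from compound 1 to compound 3 (within the scatter), that is, nothing beyond the scatter in either direction. Compound 3 is therefore estimated at 40% in this assay, with a range from 25% to 55%.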

Compound 3, a percentage reported as inhibition, in the whole organism at one dose (the size of the read-out at that dose, not a potency): 36.2%
Compound 3: the middle estimate sits 3.8 percentage points above what was measured; the measured number falls inside the stated range.
By their numbers in this assay, from the lowest: compounds 3, 2 and 1 (each within the scatter of the next).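

For the compounds shown here, compound 1 and compound 3 are the first pair that differs in one place, so the group on the double-bonded nitrogen can now be read directly: with 2-chlorophenyl in place of 4-chlorophenyl, this assay records a number 5.5 percentage points lower from compound 1 to compound 3 (within the scatter), and the two values cannot be separated. For this pair, then, where the chlorine stands on the phenyl ring makes no difference that this measurement can resolve, although a single pair at a single dose shows no more than that. Nothing available bears on why these two compounds read alike.

As far as these compounds go, what an amine or a carboxylic acid on the phenyl ring, or a longer chain in place of that ring, would do at this position stays open, as does whether any group there could move the number beyond the scatter. Equally open, from the compounds shown here alone, is what a change elsewhere on the shared core would do, and whether the reading for this pair would hold at another dose.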